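Methyl for Chloro on a Shared Phenol Core

This account rests on a few compounds, and the source may have more. Where it says the series, first, only, none or still open, it means among the compounds named here.

Compound 1, `CCNCc1cc(C)cc(Nc2nc3ccccc3n2Cc2ccc(C(F)(F)F)cc2)c1O`, gives 98% in an ADME assay on microsomes from liver (Homo sapiens) for metabolic stability, read by LC-MS, with a stated time of 30 min, tested at 1 uM; a higher number here means that more of the compound is left, a lower number that less of the compound is left.
Compound 2, `CCNCc1cc(Cl)cc(Nc2nc3ccccc3n2Cc2ccc(C(F)(F)F)cc2)c1O`, gives 94% in this assay.
Compound 3, `CCNCc1cc(Cl)cc(Nc2nc3cc(F)c(F)cc3n2Cc2ccc(C(F)(F)F)cc2)c1O`, shows in this assay only a limit of the assay, > 99%.

The change from compound 2 to compound 1 is methyl in place of chloro on an aromatic carbon. In this assay this gave a number 4 percentage points higher from compound 2 to compound 1 (within the scatter), so the two values are not distinguished here. Compound 3 and compound 2 carry different cores; the difference between the two cores is not broken down here. Compound 3 stands at a limit, as the limit of > 99% in this assay, at which 1 of the 3 values shown sits, shows.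

Compound 4, `CCNCc1cc(C)cc(Nc2nc3cc(F)c(F)cc3n2Cc2ccc(C(F)(F)F)cc2)c1O`, is not yet measured. It differs from compound 3 by methyl in place of chloro on an aromatic carbon, the same change as that from compound 2 to compound 1, at the same place. For compound 4 a step of a number at least 2 percentage points lower from compound 3 to compound 4 (that floor lies within the scatter) is expected, because a number 4 percentage points higher from compound 2 to compound 1 (within the scatter) lay within the scatter and compound 3 already sits at a limit. Compound 4 is therefore estimated at 97% in this assay, with a fair chance that only a limit is reported again.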

Compound 4, percent of the compound remaining: 99%
Estimate against measurement, compound 4: 2 percentage points below; the range from low to high includes it.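

In this assay methyl in place of chloro on an aromatic carbon gave a number no higher from compound 3 to compound 4 (the limit leaves the size open) as the new step.

Set side by side, methyl in place of chloro on the two cores gives this picture in this assay: the same change on two cores in this assay, a number 4 percentage points higher (within the scatter) from compound 2 to compound 1 and a number no higher (the limit leaves the size open) from compound 3 to compound 4; the limit leaves it open whether they differ

The size of the new step cannot be read, and the value of compound 3 is a limit of the assay, not a number: the limit of > 99% in this assay, at which 1 of the 4 values shown sits.

The series therefore shows that the change left no readable difference on the core of compound 1, but it does not show whether the change carries over to the core of compound 3 with the same size or a different one.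

The compounds shown leave open what another group para to the hydroxy group, such as a nitrile or a methoxy group, would give in this assay. They also leave open what a longer chain in place of the (ethylamino)methyl group would give, and how the change would compare across cores on a compound that stands clear of the limit.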